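A few compounds are considered here, and "the series" means these few. Any claim that something is new, unique, unknown or untested is made for them only; others in the source may bear on it.

In a physicochemical assay for solubility, read by chemiluminescence, measured as kinetic solubility (a higher number here means a more soluble compound, a lower number a less soluble compound), compound 3 `COc1nn(C)c2nc(N)nc(NS(=O)(=O)c3cccc(Cl)c3Cl)c12` stands only at a limit, not at a true number: >= 649000 nM. Compound 1 `COc1nn(C)c2ncnc(NS(=O)(=O)c3cccc(Cl)c3Cl)c12` also gives only a limit: >= 581000 nM. Compound 2 `COc1nn(C)c2nc(C)nc(NS(=O)(=O)c3cccc(Cl)c3Cl)c12` likewise gives only a limit: >= 557000 nM. Compound 4 `CNc1nc(NS(=O)(=O)c2cccc(Cl)c2Cl)c2c(OC)nn(C)c2n1` differs from compound 3 by one change: methyl in place of hydrogen on a nitrogen on an aromatic ring, or amino to methylamino. Going by the values given here, three measured steps bear on it: a step that the two limits leave unreadable from compound 1 to compound 2 and a step that the two limits leave unreadable from compound 1 to compound 3 and a step that the two limits leave unreadable from compound 2 to compound 3. None of these has a readable size, so no step beyond the scatter is expected, in either direction. The expected step is an at least 1.1-fold lower number from compound 3 to compound 4 (0.04 log units; that floor lies within the scatter). Compound 4 is estimated at 580000 nM, with an expected range from 300000 nM to 700000 nM.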

Compound 4, solubility: 376000 nM
For compound 4 the middle estimate is 1.5-fold (0.19 log units) above the measured one, and the stated range covers the measured number.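

In this assay methylamino on this nitrogen gives the only true number among the compounds shown, while the hydrogen, methyl and amino compounds stand at limits. The steps of an at least 1.7-fold lower number from compound 3 to compound 4 (0.23 log units; that floor lies within the scatter) and an at least 1.4-fold lower number from compound 2 to compound 4 (0.17 log units; that floor lies within the scatter) and an at least 1.5-fold lower number from compound 1 to compound 4 (0.18 log units; that floor lies within the scatter) are all floors within the scatter, so no real drop is shown and the full size of each stays unknown. The floor on the amino to methylamino change rests on a limit: the limit of >= 649000 nM in this assay, at which 1 of the 4 values shown sits.

From the compounds shown here alone, whether a longer chain such as ethylamino, or dimethylamino, would give a clearly lower number stays open.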